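This account rests on a few compounds, and the source may have more. Where it says the series, first, only, none or still open, it means among the compounds named here.

Three compounds built on the core of compound 1 `Nc1ccccc1NC(=O)/C=C/c1ccc(CSc2ccc(F)cc2)cc1` have been tested in a functional assay on A-375 cells (Homo sapiens) for inhibition, read by CCK-8 assay, with a stated time of 72 h, tested at 8 uM; a higher number here means more inhibition of growth at the concentration tested, a lower number less inhibition of growth. Compound 1 gives 24.6%, the second highest of the three numbers. Compound 2 `Nc1ccccc1NC(=O)c1ccc(CSc2ccc(C(F)(F)F)cn2)cc1` gives 5.34%, lower than compound 1 by more than the scatter, while compound 3 `Nc1ccccc1NC(=O)c1ccc(CSc2cccc(F)c2)cc1` gives 76.3%, higher than compound 1 by more than the scatter. Compound 4 `Nc1ccccc1NC(=O)/C=C/c1ccc(CSCCc2ccccc2)cc1` has not yet been tested in this assay. It differs from compound 1 in one place: phenethyl in place of 4-fluorophenyl on a sulfur. Going by the values given here, no measured pair differs in this way, so the data give no step of the same kind to lean on. The expected step, a number 0.4 percentage points higher from compound 1 to compound 4 (within the scatter), is small and not clearly beyond the scatter in either direction. Compound 4 is therefore estimated to give about 25% in this assay, between 8% and 50%.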

Compound 4, percent growth inhibition at one concentration: 37.4%
The estimate for compound 4 lay 12.4 percentage points below the measured number; the measured number falls inside the stated range.
By their numbers in this assay, from the lowest: compound 2; then compound 1; then compound 4; then compound 3.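

Phenethyl in place of 4-fluorophenyl on a sulfur gives a number 12.8 percentage points higher from compound 1 to compound 4 (beyond the scatter) in this assay, the first single-place change at this position. Here, the sulfur tolerates a group without fluorine whose ring is carried on a chain, with no loss of growth inhibition. No measurement available explains the rise.

Going by these compounds alone, the single step removes the fluorine and adds the chain together, so their separate contributions remain unresolved. An unsubstituted phenyl, a benzyl or a longer chain ending in an amine on the sulfur would help to separate them.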